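The compounds below may be only part of what the source reports. "The series", "measured", "known", "first", "only" and "open" are said of these compounds alone.

Compound 1 `CCCN(CC1CC1)c1cc(Cc2c(OC)cc(OC)cc2OC)nc(C)n1` is the reference point of this small set. In an assay on isolated protein for binding affinity to corticotropin-releasing factor receptor 1 (Homo sapiens) (a higher number here means a weaker inhibitor, a lower number a stronger inhibitor), compound 1 gives 26 nM, the lowest number among the three compounds that have been measured. Compound 2 `CCCN(CC1CC1)c1cc(C(O)c2c(C)cc(C)cc2C)nc(C)n1` carries a hydroxyl group on the carbon that links the two ring systems, and in this assay compound 2 gives 79 nM. Compound 3 `CCCN(CC1CC1)c1cc(C(O)c2c(CC)cc(CC)cc2CC)nc(C)n1` shares that hydroxyl but bears a differently substituted aromatic ring, and in this assay compound 3 gives 360 nM. Both of these numbers lie beyond the usual scatter from the number for compound 1. Among the measured compounds shown here, compounds 2 and 3 also differ from compound 1 in their aromatic rings; their values show only that those combinations of changes weakened binding.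

For the measured compounds named here, compound 4 `CCCN(CC1CC1)c1cc(C(C)c2c(OC)cc(OC)cc2OC)nc(C)n1` is the one change to compound 1 that has not yet been measured: methyl in place of hydrogen on a saturated chain carbon bound to two aromatic carbons. Going by the values given here, no directly comparable pair of measured compounds shows what such a change does here. The hydroxyl-bearing compounds 2 and 3 at least indicate that this carbon accepts a substituent without loss of all binding. The step from compound 1 to compound 4 is therefore expected to be small, a 1.3-fold higher number from compound 1 to compound 4 (0.13 log units; within the scatter), likely within or only slightly beyond the scatter. Compound 4 is thus estimated at 35 nM, with a plausible range from 10 nM to 120 nM.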

Compound 4, inhibition constant: 480 nM
The estimate for compound 4 lay 14-fold (1.14 log units) below the measured number; the whole stated range lies below it.
By their numbers in this assay, from the lowest: compound 1; then compound 2; then compounds 3 and 4 (each within the scatter of the next).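

In this assay, methyl in place of hydrogen on a saturated chain carbon bound to two aromatic carbons gives an 18-fold higher number from compound 1 to compound 4 (1.27 log units; beyond the scatter) and so marks a large weakening of binding. This carbon is therefore sensitive to substitution in this series: adding one carbon, with the rest of compound 1 unchanged, is enough to produce a step of this size. Compounds 2 and 3 could not show this, as each differs from compound 1 both at this carbon and in the aromatic ring, whereas compound 1 and compound 4 differ in this one place. Nothing measured here accounts for the size of this step.

Still open, from the compounds shown here alone, is what a hydroxyl group alone would do at this carbon when the aromatic ring of compound 1 is kept, as the hydroxyl appears here only together with a different ring. Going by these compounds, it is also open whether a fluorine atom or a longer chain such as ethyl on this carbon would weaken binding to a similar degree.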